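The source may report more compounds than this note shows. Statements on the series, on what has been measured and on what is new or still open speak of the compounds shown alone.

Working notes on the series. Compound 1 `COc1ccc(-n2nc(C(=O)Nc3ccccc3OC)nc2-c2cc(OC)c(OC)c(OC)c2)cc1` and compound 2 `COc1ccc(-n2nc(C(=O)Nc3cccc(F)c3)nc2-c2cc(OC)c(OC)c(OC)c2)cc1` share one core and have been tested in a functional assay on the whole organism for inhibition, with Rattus norvegicus as the target, read by paw edema, with stated times of 30 min and 3 h, at a dose of 0.28 mmol/kg by the oral route; on this read-out higher numbers stand for more inhibition at the one dose given (going by the name of the read-out) and lower numbers for less inhibition. In this assay, within the data shown here, compound 1 gives 44%, the lowest of the two numbers so far, and compound 2 gives 106%. Among the measured compounds shown here, the one measured step, a number 62 percentage points higher from compound 1 to compound 2 (beyond the scatter), shows that exchanging the 2-methoxyphenyl on the amide-type nitrogen can move the read-out a long way. Compound 3 `COc1ccc(-n2nc(C(=O)Nc3ccc(C(=O)O)cc3)nc2-c2cc(OC)c(OC)c(OC)c2)cc1` is the next member to be measured: it differs from compound 1 by 4-carboxyphenyl in place of 2-methoxyphenyl on an amide-type nitrogen. For the measured compounds named here, only the step from compound 1 to compound 2 bears on this change, and it concerns a different entering group, so it indicates direction rather than size. Compound 3 is therefore expected to lie above compound 1, with a number 21 percentage points higher from compound 1 to compound 3 (beyond the scatter) as the estimated step, though a smaller gain than compound 2 showed would not surprise. The estimate for compound 3 is 65%, within 30% to 100%.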

Compound 3, a percentage reported as inhibition, in the whole organism at one dose (the size of the read-out at that dose, not a potency): 109%
For compound 3 the middle estimate is 44 percentage points below the measured one, outside the stated range (above it).
By their numbers in this assay, from the lowest: compound 1; then compounds 2 and 3 (each within the scatter of the next).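

The gain on replacing the 2-methoxyphenyl on the amide-type nitrogen is not tied to a single entering group: in this assay 4-carboxyphenyl also gives a large rise, a number 65 percentage points higher from compound 1 to compound 3 (beyond the scatter). Compound 2 and compound 3 cannot be separated in this read-out, with a number 3 percentage points higher from compound 2 to compound 3 (within the scatter), so 3-fluorophenyl and 4-carboxyphenyl give matching results here despite being different groups. No measurement at hand accounts for this result.

Still open, as far as these compounds go, is whether the low number of compound 1 belongs to the methoxy group itself or to the 2-methoxyphenyl arrangement as a whole, since both entering groups differ from it in substituent and in where that substituent sits. An unsubstituted phenyl, a 4-methoxyphenyl or a 4-aminophenyl on the same nitrogen would help to separate these readings.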